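The source may report more compounds than this note shows. Statements on the series, on what has been measured and on what is new or still open speak of the compounds shown alone.

In a functional assay on HPAC cells (Homo sapiens) for inhibition, read by MTT assay, with a stated time of 72 h (on this read-out lower numbers stand for stronger inhibition of growth and higher numbers for weaker inhibition of growth), compound 1 `O=S(=O)(NCCCNCc1ccccc1Cl)c1cc(C(F)(F)F)cc(C(F)(F)F)c1` gives 10000 nM, and compound 2 `O=S(=O)(NCCCNCc1ccc(-c2ccccc2)cc1)c1cc(C(F)(F)F)cc(C(F)(F)F)c1` gives 2700 nM; of these two numbers compound 2 stands lower, and its gap to compound 1 lies beyond the scatter. Compound 3 `O=S(=O)(NCCCNCc1ccc(Cl)cc1)c1cc(C(F)(F)F)cc(C(F)(F)F)c1` differs from compound 2 by chloro in place of phenyl on an aromatic carbon. Going by the values given here, no measured pair shows the effect of this change on the shared core, so the expectation rests on the two numbers alone. A modest rise in this assay, expected as a 2.2-fold higher number from compound 2 to compound 3 (0.35 log units; beyond the scatter), seems plausible. Compound 3 is therefore estimated at 6000 nM, with a range from 2500 nM to 15000 nM.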

Compound 3, concentration for 50% growth inhibition: 2800 nM
The estimate for compound 3 lay 2.1-fold (0.33 log units) above the measured number, within the range that was stated.
By their numbers in this assay, from the lowest: compounds 2 and 3 (each within the scatter of the next); then compound 1.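

In this assay chloro in place of phenyl on this aromatic carbon gives a 1.0-fold higher number from compound 2 to compound 3 (0.02 log units; within the scatter) and so shows that, in this pair, a single chlorine atom serves as well as a whole phenyl ring. 4-Chlorophenyl in place of 2-chlorophenyl gives a 3.6-fold lower number from compound 1 to compound 3 (0.55 log units; beyond the scatter) and so shows that the place of the chlorine on that ring matters here. No measurement at hand explains either step.

Open, as far as these compounds go, is whether an amine, a methoxy group or a carboxylic acid on this same aromatic carbon would match chloro and phenyl, or shift the number.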